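A few compounds are considered here, and "the series" means these few. Any claim that something is new, unique, unknown or untested is made for them only; others in the source may bear on it.

Working notes on the series.

Compound 3 `Nc1ccc(Nc2nc3ccccc3nc2S(=O)(=O)c2ccc(Br)cc2)cc1` in a functional assay on PC-3 cells (Homo sapiens) for cytotoxicity, read by MTT assay, with a stated time of 72 h (a higher number here means a weaker inhibitor, a lower number a stronger inhibitor), gives 2330 nM. Within the data shown here, compound 1 `Nc1cccc(Nc2nc3ccccc3nc2S(=O)(=O)c2ccccc2)c1` in this assay gives 2150 nM, and compound 2 `Cc1ccc(S(=O)(=O)c2nc3ccccc3nc2Nc2cccc(N)c2)cc1` gives 2000 nM; all three numbers lie within the scatter of one another, so no compound can be set apart. Among the measured compounds shown here, the one single-point step recorded, a 1.1-fold lower number from compound 1 to compound 2 (0.03 log units; within the scatter), changes nothing beyond the scatter.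

Compound 4 `Nc1cccc(Nc2nc3ccccc3nc2S(=O)(=O)c2ccc(Br)cc2)c1` is not yet measured. It differs from compound 3 by 3-aminophenyl in place of 4-aminophenyl on a nitrogen on an aromatic ring. For the measured compounds named here, no recorded step isolates this change; compound 1 carries the 3-aminophenyl group already, but it also lacks the bromine of compound 3, so the pair differs in two places, and their two values are within the scatter of each other. Going by the values given here, the only direct evidence is that the recorded step a 1.1-fold lower number from compound 1 to compound 2 (0.03 log units; within the scatter) and the two-place pair of compound 1 and compound 3 both show no movement beyond the scatter.

The expectation for compound 4 is therefore no step beyond the scatter, a 1.1-fold lower number from compound 3 to compound 4 (0.02 log units; within the scatter). Compound 4 is estimated at 2200 nM, with a range from 1000 nM to 4800 nM.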

Compound 4, half-maximal inhibitory concentration: 9010 nM
For compound 4 the middle estimate is 4.1-fold (0.61 log units) below the measured one; measured number above the stated range.
By their numbers in this assay, from the lowest: compounds 2, 1 and 3 (each within the scatter of the next); then compound 4.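

In this assay, among these compounds, a 3.9-fold higher number from compound 3 to compound 4 (0.59 log units; beyond the scatter): with bromo on the sulfonyl-bearing ring, the change from (4-aminophenyl)amino to (3-aminophenyl)amino is the first single-place change to move beyond the scatter. With the 3-aminophenyl group held constant, the aromatic carbon also proves sensitive, since a 4.2-fold higher number from compound 1 to compound 4 (0.62 log units; beyond the scatter) for bromo in place of hydrogen and a 4.5-fold higher number from compound 2 to compound 4 (0.65 log units; beyond the scatter) for bromo in place of methyl, whereas methyl in place of hydrogen had stayed within the scatter. Nothing available explains these steps.

The compounds shown leave open whether the bromo steps also appear with the 4-aminophenyl group, since that group occurs here only with bromo. They also leave open how chloro or methoxy at the bromo position, or hydroxyl in place of the amine, would read in this assay.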